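The compounds below may be only part of what the source reports. "The series", "measured", "known", "first", "only" and "open" are said of these compounds alone.

Working notes on the selenium series in a functional assay on HT-29 cells (Homo sapiens) for cytotoxicity, read by MTT assay, with a stated time of 72 h; on this read-out higher numbers stand for lower toxicity in this test and lower numbers for higher toxicity in this test.

Three members have been measured. Compound 1 `CCCCC[Se]c1nc(N)c2ccccc2n1` in this assay gives > 100000 nM, which is a limit of the assay rather than a number. Compound 2 `COc1ccc(CNc2nc([SeH])nc3ccccc23)cc1` in this assay gives > 100000 nM, again a limit. Compound 3 `CCCCC[Se]c1nc(NCc2ccccc2)c2ccccc2n1` in this assay gives > 100000 nM, also a limit. Compound 3 therefore stands at the limit with no number of its own, and all three measured values sit there, as the limit of > 100000 nM in this assay, at which 3 of the 3 values shown sit, shows.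

For the measured compounds named here, the one step between measured compounds that differ in a single place, a step that the two limits leave unreadable from compound 1 to compound 3, runs between two limits and is unreadable.

Compound 4 `[SeH]c1nc(NCc2ccccc2)c2ccccc2n1` is not yet measured. It differs from compound 3 as hydrogen in place of pentyl on a selenium. Going by the values given here, no measured step touches the selenium, so no step gives a size for this change. Among the compounds with values here, the only bearing is that compound 2, which also carries hydrogen on a selenium, gives > 100000 nM, a limit. Compound 4 is therefore expected to remain at the limit, with the step that the limit leaves unreadable from compound 3 to compound 4 expected to lie within the scatter. The estimate for compound 4 is 150000 nM, within 50000 nM to 500000 nM.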

Compound 4, concentration lethal to 50% of the cells: > 100000 nM
Compound 4 gave a limit, no number; the forecaster's own chance of this, stated with the estimate: 80%; the middle value is on the limit's open side.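

The steps to compound 4 from compound 2 and from compound 3 run between limits, so no new step can be read: the limit of > 100000 nM in this assay, at which 4 of the 4 values shown sit.

The compounds shown leave open which change, if any, would bring a value inside the range of this assay.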